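This account rests on a few compounds, and the source may have more. Where it says the series, first, only, none or still open, it means among the compounds named here.

Series notes. Compound 1 `O=[N+]([O-])c1cn2c(n1)OC(CNc1ccc(OC(F)(F)F)cc1)CC2` carries the shared core; compound 2 `CC1(CNc2ccc(OC(F)(F)F)cc2)CCn2cc([N+](=O)[O-])nc2O1` differs from it by methyl in place of hydrogen on a saturated ring carbon. In an ADME assay on MRC5 cells (Homo sapiens) for cytotoxicity, read by resazurin assay, with a stated time of 72 h (a higher number here means a weaker inhibitor, a lower number a stronger inhibitor), compound 1 reaches only the limit of the method, giving >= 40000 nM. Compound 2 likewise gives only a limit in this assay, >= 40000 nM. The step that the two limits leave unreadable from compound 1 to compound 2 therefore cannot be read, since the limit of >= 40000 nM in this assay, at which 3 of the 3 values shown sit, holds both of its ends.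

Compound 3 `O=C(NCc1ccc(OC(F)(F)F)cc1)OCC1CCn2cc([N+](=O)[O-])nc2O1` carries a different linker to the aryl group; the difference between the cores of compound 1 and compound 3 is not broken down here. Compound 3 also gives only a limit in this assay, >= 40000 nM.

Compound 4 `CC1(COC(=O)NCc2ccc(OC(F)(F)F)cc2)CCn2cc([N+](=O)[O-])nc2O1` is not yet measured; it differs from compound 3 by methyl in place of hydrogen on a saturated ring carbon, the same change as that from compound 1 to compound 2, at a place described in the same words. For compound 4 the step expected in this assay is a number no higher from compound 3 to compound 4 (the limit leaves the size open), because compound 3 sits at the limit of >= 40000 nM in this assay, at which 3 of the 3 values shown sit, and the earlier step that the two limits leave unreadable from compound 1 to compound 2 is unreadable. Compound 4 is therefore expected to give 40000 nM in this assay, most probably again reported only as a limit, within a range of 20000 nM to 80000 nM.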

Compound 4, half-maximal inhibitory concentration: >= 40000 nM
Compound 4: no number, only a limit (the forecaster's own chance of this, stated with the estimate: 85%); the middle value lies on the limit itself.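

No new step can be read: compound 3 and compound 4 both give only a limit in this assay, as do the other compounds, which places all of them at the same reading: the limit of >= 40000 nM in this assay, at which 4 of the 4 values shown sit.

The compounds shown leave open whether methyl in place of hydrogen on a saturated ring carbon shifts this read-out at all, as none of them gives a number.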